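The compounds below may be only part of what the source reports. "The series", "measured", "known", "first", "only" and "open" are said of these compounds alone.

The series rests on a shared core that carries a pyrazole-linked pyridine bearing a para-substituted phenyl, and the read-out is a functional assay on DU-145 cells (Homo sapiens) for cytotoxicity, read by sulforhodamine B assay, with a stated time of 48 h, tested at 10 uM; on this read-out lower numbers stand for a stronger effect and higher numbers for a weaker effect at the one concentration tested. Compound 1, `COc1cc(C)cc(-c2c(-c3ccnc(-c4ccc(C(C)=O)cc4)c3)cnn2CC#N)c1`, gives 15% in this assay, the highest of the two numbers recorded, and it stands apart from its nearest neighbour, compound 2, `Cc1cc(O)cc(-c2nn(CC#N)cc2-c2ccnc(-c3ccc(N(C)C)cc3)c2)c1`, which gives -66% in this assay, a gap that lies beyond the scatter. Compound 2 differs from compound 1 in more than one place, so the two values speak only for themselves and no single change can be read from them.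

Compound 3, `COc1cc(C)cc(-c2c(-c3ccnc(-c4ccc(N(C)C)cc4)c3)cnn2CC#N)c1`, has not yet been measured in this assay. It is compound 1 with one alteration, (dimethylamino in place of acetyl on an aromatic carbon), set on an aromatic carbon of a six-membered aromatic ring of carbon only, para to a large group. Compound 2 also carries the dimethylamino group on that ring, and its value of -66% in this assay is the only pointer available. On that basis compound 3 is expected to show a downward step of a number 45 percentage points lower from compound 1 to compound 3 (beyond the scatter), and its value is estimated at -30%, within a range from -70% to 10%.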

Compound 3, a percentage reported as activity, at one concentration (the size of the read-out at that concentration, not a potency): -48%
The estimate for compound 3 lay 18 percentage points above the measured number, and the stated range covers the measured number.
By their numbers in this assay, from the lowest: compound 2; then compound 3; then compound 1.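

Among these compounds, compound 3 gives the first reading of a single change on the shared core: with dimethylamino in place of acetyl on an aromatic carbon of a six-membered aromatic ring of carbon only, para to a large group, this assay shows a number 63 percentage points lower from compound 1 to compound 3 (beyond the scatter). This shows that this position alone can carry a large shift in the read-out, which the earlier pair could not show since its members differ in more than one place. The step comes with no change in the count of heavy atoms, hydrogen-bond donors or hydrogen-bond acceptors, and nothing measured here says what lies behind it.

Going by these compounds, whether a primary amine, a methoxy group or a carboxylic acid in the same place would fall near compound 1 or near compound 3 remains open, since this one pair sets only two points at this position. Steps involving compound 2 cannot be read, so it also remains open whether the exchange of acetyl for dimethylamino would give a similar shift with other groups elsewhere on the core.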